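From 4-(1-hydroxyethyl)phenoxy to 3-aminophenoxy on a shared core

A few compounds are considered here, and "the series" means these few. Any claim that something is new, unique, unknown or untested is made for them only; others in the source may bear on it.

In a functional assay on CCRF-CEM cells (Homo sapiens) for antiproliferative activity, read by cell counting, with a stated time of 96 h (on this read-out higher numbers stand for weaker inhibition and lower numbers for stronger inhibition), compound 1 (`CC(Nc1ccccc1Oc1ccc(Cl)cc1)=C1C(=O)CC(c2ccccc2)CC1=O`) gives 190 nM, and compound 2 (`CC(Nc1ccccc1Oc1ccc(C(C)O)cc1)=C1C(=O)CC(c2ccccc2)CC1=O`) gives 120 nM. For the measured compounds named here, compound 2 therefore stands level with the only other measured compound, as the two numbers lie within the scatter of each other. Compound 3 (`CC(Nc1ccccc1Oc1cccc(N)c1)=C1C(=O)CC(c2ccccc2)CC1=O`) keeps the shared core and differs from compound 2 at one place: 3-aminophenyl in place of 4-(1-hydroxyethyl)phenyl on an oxygen on an aromatic ring. In words, this is 3-aminophenyl in place of 4-(1-hydroxyethyl)phenyl on an oxygen on an aromatic ring. Going by the values given here, the only measured step that bears on this change is a 1.6-fold lower number from compound 1 to compound 2 (0.20 log units; within the scatter), where 1-hydroxyethyl stands in place of chloro on an aromatic carbon. Among the compounds with values here, no measured compound carries an amino group, so that small step is weak guidance. The expected change is a 1.3-fold higher number from compound 2 to compound 3 (0.10 log units; within the scatter), which means no shift beyond the scatter in either direction. Compound 3 is estimated at 150 nM, with an expected range from 50 nM to 450 nM.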

Compound 3, half-maximal inhibitory concentration: 42 nM
Compound 3: the middle estimate sits 3.6-fold (0.55 log units) above what was measured; the measured number lies below the stated range.
By their numbers in this assay, from the lowest: compound 3; then compounds 2 and 1 (each within the scatter of the next).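

In this assay, the group on the oxygen on an aromatic ring proves able to move the number beyond the scatter, which the exchange of chloro for 1-hydroxyethyl did not show: 3-aminophenyl in place of 4-(1-hydroxyethyl)phenyl gives a 2.9-fold lower number from compound 2 to compound 3 (0.46 log units; beyond the scatter), and 3-aminophenyl in place of 4-chlorophenyl gives a 4.5-fold lower number from compound 1 to compound 3 (0.66 log units; beyond the scatter). Both steps are modest and run the same way, leaving compound 3 with the lowest number of the three. Nothing given here accounts for this difference.

As far as these compounds go, whether the step belongs to the amino group itself or to the place it holds on the ring stays open, since the two change together in these compounds. Also open, from the compounds shown here alone, is how a dimethylamino group, a carboxylic acid or a plain phenyl would behave at this position.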